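The source may report more compounds than this note shows. Statements on the series, on what has been measured and on what is new or still open speak of the compounds shown alone.

The compounds share one core, carrying two aryl groups on its two double-bonded chain carbons. Compound 1 `C=CCn1c(=O)/c(=C\c2ccc(Cl)c(Cl)c2)[nH]c(=O)/c1=C\c1ccccc1` is reported in a functional assay on HL-60 cells (Homo sapiens) for cytotoxicity, read by CCK-8 assay, with a stated time of 72 h (on this read-out higher numbers stand for weaker inhibition and lower numbers for stronger inhibition), as "not active" (no number reported). Among the measured compounds shown here, compound 2 `COc1ccccc1/C=c1\c(=O)[nH]/c(=C/c2ccccc2Cl)c(=O)n1C` gives in this assay a value of 200 nM, the only number among the three measured compounds. Like compound 1, compound 3 `C=CCn1c(=O)/c(=C\c2ccc(F)c(Br)c2)[nH]c(=O)/c1=C\c1ccccc1OC` is reported in this assay as "not active" (no number reported), so no number fixes where it stands; it sits with compound 1 among the entries without a value, while compound 2 alone shows measurable inhibition.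

Compound 4 `C=CCn1c(=O)/c(=C\c2ccccc2F)[nH]c(=O)/c1=C\c1ccccc1OC` differs from compound 3 in one place: 2-fluorophenyl in place of 3-bromo-4-fluorophenyl on a double-bonded chain carbon bound to an aromatic carbon. Compound 3 carries no number in this assay. For the measured compounds named here, the size of this step cannot be computed, and no step between measured compounds exists to guide it. Given only that compound 2 returns 200 nM while compounds 1 and 3 return nothing, the direction of the change is open. Compound 4 is expected to land near 1500 nM, within a wide band from 200 nM to 15000 nM, with a real chance that no number is reported.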

Compound 4, half-maximal inhibitory concentration: 18500 nM
Compound 4: the middle estimate sits 12-fold (1.09 log units) below what was measured; measured number outside the range, above it.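

Among the compounds shown here, compound 3 carries no number in this assay while compound 4 gives 18500 nM so no step between these two compounds can be read. No measurement shown here explains this result. The compounds shown leave open how replacing 3-bromo-4-fluorophenyl with 2-fluorophenyl alters inhibition.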